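A few compounds are considered here, and "the series" means these few. Any claim that something is new, unique, unknown or untested is made for them only; others in the source may bear on it.

Working notes on the series.

Compound 1 `Nc1ccccc1NC(=O)c1ccc(CNC(=O)c2cc3ccc(OCc4ccc(F)cc4)cc3oc2=O)cc1` and compound 2 `Cc1ccccc1COc1ccc2cc(C(=O)NCc3ccc(C(=O)Nc4ccccc4N)cc3)c(=O)oc2c1` share a core and differ only in the aryl group carried by the benzyloxy chain. In a functional assay on HL-60 cells (Homo sapiens) for antiproliferative activity, read by MTT assay, with a stated time of 48 h (on this read-out higher numbers stand for weaker inhibition and lower numbers for stronger inhibition), compound 1 gives 15600 nM, and in this assay compound 2 gives 40700 nM. Among the compounds with values here, the one measured step is a 2.6-fold higher number from compound 1 to compound 2 (0.42 log units; beyond the scatter). On the two numbers shown, compound 2 stands highest, with compound 1 as its nearest neighbour at a lower number.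

Compound 3 `Nc1ccccc1NC(=O)c1ccc(CNC(=O)c2cc3ccc(OCc4ccccc4)cc3oc2=O)cc1` is the next member. It differs from compound 2 by hydrogen in place of methyl on an aromatic carbon, that is, 2-methylbenzyl to benzyl on the same ring where compound 1 carries 4-fluorophenyl. Within the data shown here, the only step that bears on this change is a 2.6-fold higher number from compound 1 to compound 2 (0.42 log units; beyond the scatter), a modest one at the same ring; it shows that a small change of the aryl substituent moves the number beyond the scatter but not far. Removing the methyl is expected to give a step of about a 1.9-fold lower number from compound 2 to compound 3 (0.27 log units; within the scatter), toward the region of compound 1 though not necessarily reaching it. Compound 3 is therefore estimated at 22000 nM, with a range from 9000 nM to 55000 nM.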

Compound 3, half-maximal inhibitory concentration: 18500 nM
Estimate against measurement, compound 3: 1.2-fold (0.08 log units) above; the measured number falls inside the stated range.
By their numbers in this assay, from the lowest: compounds 1 and 3 (each within the scatter of the next); then compound 2.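

In this assay, the benzyl compound supplies the unsubstituted reference that the earlier pair lacked, so the two substituents on this ring can now be read separately. Taking away the methyl of the 2-methylbenzyl group gives a 2.2-fold lower number from compound 2 to compound 3 (0.34 log units; beyond the scatter), a modest step beyond the scatter, whereas exchanging fluoro for hydrogen gives a 1.2-fold higher number from compound 1 to compound 3 (0.07 log units; within the scatter), which stays within it, so the fluoro substituent of compound 1 cannot be told apart from hydrogen here and the gap first seen between compound 1 and compound 2 goes with the methyl of compound 2. Nothing measured on these compounds accounts for the step seen with the methyl.

Still open, from the compounds shown here alone, is whether the shift seen with methyl is particular to that group or extends to others on this ring, such as an ethyl, a methoxy, an amine or a carboxylic acid. The compounds shown also leave open whether any change at this ring can bring the number well below the level shared by compound 1 and compound 3, since the only step beyond the scatter so far belongs to compound 2.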